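This account rests on a few compounds, and the source may have more. Where it says the series, first, only, none or still open, it means among the compounds named here.

Compound 1 `N=C(Nc1cccc(C(F)(F)F)c1)c1cc2c(-c3ccccc3)n[nH]c2cn1`: 24600 nM
Compound 2 `Cn1nc(-c2ccccc2)c2cc(C(=N)Nc3cccc(C(F)(F)F)c3)ncc21`: 17800 nM

In a functional assay on HT-1080 cells (Homo sapiens) for cytotoxicity, read by MTT assay, with a stated time of 72 h (a lower number here means a stronger inhibitor, a higher number a weaker inhibitor), compound 1 gives 24600 nM and compound 2 gives 17800 nM. Of these two numbers compound 2 holds the lower, yet the step of a 1.4-fold lower number from compound 1 to compound 2 (0.14 log units; within the scatter) lies within the scatter, so the two are not separated. Compound 3 `COc1ccc(Cn2nc(-c3ccccc3)c3cc(C(=N)Nc4cccc(C(F)(F)F)c4)ncc32)cc1` differs from compound 2 by 4-methoxyphenyl in place of hydrogen on a saturated chain carbon bound to an aromatic nitrogen. Among the measured compounds shown here, the only measured step that touches this nitrogen is a 1.4-fold lower number from compound 1 to compound 2 (0.14 log units; within the scatter), and it was small. For the measured compounds named here, no measured step adds a group of this size there, so only a modest shift in this assay is expected. Compound 3 is estimated at 15000 nM, the expected step being a 1.2-fold lower number from compound 2 to compound 3 (0.07 log units; within the scatter), within 5000 nM to 45000 nM.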

Compound 3, half-maximal inhibitory concentration: 46700 nM
Estimate against measurement, compound 3: 3.1-fold (0.49 log units) below; measured number above the stated range.
By their numbers in this assay, from the lowest: compounds 2, 1 and 3 (each within the scatter of the next, the first and the last beyond it).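

Among the compounds shown here, with 4-methoxybenzyl on the aromatic nitrogen, this assay gives the first step here that lies beyond the scatter, namely a 2.6-fold higher number from compound 2 to compound 3 (0.42 log units; beyond the scatter), whereas methyl in place of hydrogen had left compound 1 and compound 2 unseparated. Measured against hydrogen on that nitrogen, the same group gives a 1.9-fold higher number from compound 1 to compound 3 (0.28 log units; within the scatter) and remains within the scatter, so only its difference from methyl is resolved. Nothing available here accounts for this shift. On these data alone, it remains open how an ethyl group, a plain benzyl group or a longer chain ending in an amine would read at this nitrogen.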